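The compounds below may be only part of what the source reports. "The series", "measured", "known", "first", "only" and "open" are said of these compounds alone.

Measured compounds:
compound 1, `COc1ccc(-c2cc3ccc(OCCCCn4cc(CNC(=O)CCCCC5CCSS5)nn4)cc3oc2=O)cc1`: 48.6%
compound 2, `O=C(CCCCC1CCSS1)NCc1cn(CCCCCOc2ccc3ccc(=O)oc3c2)nn1`: 71.3%

In a functional assay on PC-12 cells (Rattus norvegicus) for cytotoxicity, read by MTT assay, with stated times of 3 h and 2 h, tested at 10 uM (on this read-out lower numbers stand for a weaker effect and higher numbers for a stronger effect at the one concentration tested), compound 1 gives 48.6%. Compound 2 gives 71.3% in this assay, the higher of the two numbers, and its gap to compound 1 lies beyond the usual scatter. Among the measured compounds shown here, these two compounds differ in more than one place, so no single step is drawn between them; only their two values are known.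

Compound 3, `Cc1cc(=O)oc2cc(OCCCCCn3cc(CNC(=O)CCCCC4CCSS4)nn3)ccc12`, has not yet been measured in this assay. It differs from compound 2 by one change: methyl in place of hydrogen on an aromatic carbon. For the measured compounds named here, no measured pair in this set differs by a change of this kind, so there is no precedent here for its size. The exchange of a methyl for a hydrogen is expected to move this assay little, and the step of a number 3.3 percentage points lower from compound 2 to compound 3 (within the scatter) is estimated to be none beyond the scatter. Compound 3 is therefore expected to give about 68% in this assay, between 50% and 85%.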

Compound 3, a percentage reported as activity, at one concentration (the size of the read-out at that concentration, not a potency): 66.3%
For compound 3 the middle estimate is 1.7 percentage points above the measured one, and the stated range covers the measured number.
By their numbers in this assay, from the lowest: compound 1; then compounds 3 and 2 (each within the scatter of the next).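

In this assay, among the compounds shown here, methyl in place of hydrogen on an aromatic carbon, at the place opposite the ring oxygen, gives a number 5 percentage points lower from compound 2 to compound 3 (within the scatter), the first single-place step in this set. On this read-out, compound 2 and compound 3 cannot be told apart, so this position carries a methyl with no effect that stands clear of the scatter. The data offer no measurement that would explain this result.

As far as these compounds go, what a larger group at this aromatic carbon would do remains open, whether an ethyl, an amine or a carboxylic acid. From the compounds shown here alone, it is also open whether the same methyl exchange would give a comparable step on the core of compound 1.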